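From 3,5-difluorophenyl to 2-bromo-5-ethoxyphenyl in growth inhibition

The compounds below may be only part of what the source reports. "The series", "measured", "known", "first", "only" and "open" are said of these compounds alone.

Compound 1 `Cc1oc2c([C@H]3CCN(C)C[C@H]3O)c(O)cc(O)c2c(=O)c1C(O)c1ccc(Cl)cc1`: 41%
Compound 2 `Cc1oc2c([C@H]3CCN(C)C[C@H]3O)c(O)cc(O)c2c(=O)c1C(O)c1c(F)cccc1Cl`: 0%
Compound 3 `Cc1oc2c([C@H]3CCN(C)C[C@H]3O)c(O)cc(O)c2c(=O)c1C(O)c1cc(F)cc(F)c1`: 0%

All three compounds were tested in a functional assay on PC-3 cells (Homo sapiens) for inhibition, read by MTT assay, with a stated time of 48 h, tested at 10 uM; on this read-out higher numbers stand for more inhibition of growth at the one concentration tested and lower numbers for less inhibition of growth. There, compound 3 gives 0% and stands level with compound 2, the comparison showing no change at the digits printed from compound 2 to compound 3 (within the scatter). Compound 4 `CCOc1ccc(Br)c(C(O)c2c(C)oc3c([C@H]4CCN(C)C[C@H]4O)c(O)cc(O)c3c2=O)c1` keeps the shared core and differs only in its aryl group: 2-bromo-5-ethoxyphenyl in place of 3,5-difluorophenyl on a saturated chain carbon bound to an aromatic carbon and an oxygen on a saturated carbon.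

Three measured steps at this same place bear on the change. Two are large, a number 41 percentage points lower from compound 1 to compound 2 (beyond the scatter) and a number 41 percentage points lower from compound 1 to compound 3 (beyond the scatter), so the group here can matter a great deal. The third shows that two different groups can give the same reading. Among the compounds with values here, no measured compound carries a bromo or an ethoxy group, so the size of the step remains uncertain. Only compound 1 reached a clearly nonzero reading, at 41%, so a return to that level seems possible but less likely.

The expected change is a number 8 percentage points higher from compound 3 to compound 4 (within the scatter), a small rise not beyond the scatter. For compound 4 the estimate is 8%, with an expected range from 0% to 30%.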

Compound 4, percent growth inhibition at one concentration: 0%
The estimate for compound 4 lay 8 percentage points above the measured number; the range from low to high includes it.
By their numbers in this assay, from the lowest: compounds 2, 3 and 4 (each within the scatter of the next); then compound 1.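

In this assay, the 2-bromo-5-ethoxyphenyl group gives no change at the digits printed from compound 3 to compound 4 (within the scatter) and no change at the digits printed from compound 2 to compound 4 (within the scatter), so a third aryl group, and the first here to carry a bromo and an ethoxy group, reads alike with the other two. The step of a number 41 percentage points lower from compound 1 to compound 4 (beyond the scatter) leaves 4-chlorophenyl as the only one of the four aryl groups at this place that stands apart, and the larger group with a hydrogen-bond acceptor does not close that gap. Nothing measured on these compounds speaks to the reason for these readings.

As far as these compounds go, it remains open whether the reading of compound 1 depends on the chloro group alone or on its place on the ring. From the compounds shown here alone, it is also open whether 4-bromophenyl, 4-methoxyphenyl or 4-aminophenyl would read like 4-chlorophenyl here.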